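Thiosemicarbazone series: chloro in place of methyl

The source may report more compounds than this note shows. Statements on the series, on what has been measured and on what is new or still open speak of the compounds shown alone.

Measured compounds in a functional assay on MCF7 cells (Homo sapiens) for cytotoxicity, read by sulforhodamine B assay; a lower number here means a stronger inhibitor of growth, a higher number a weaker inhibitor of growth:
compound 1 `CC1=CC[C@@H]([C@@](C)(O)CCCC(C)(C)NC(=S)N/N=C\c2ccccc2)CC1`: 28700 nM
compound 2 `CC1=CC[C@@H]([C@@](C)(O)CCCC(C)(C)NC(=S)N/N=C\c2ccc(C)cc2)CC1`: > 100000 nM (a limit)
compound 3 `CC1=CC[C@@H]([C@@](C)(O)CCCC(C)(C)NC(=S)N/N=C\c2cccc([N+](=O)[O-])c2)CC1`: 18300 nM

For the measured compounds named here, compound 2 stands apart from the other two: its value is only a limit, the one value sitting at the limit of > 100000 nM in this assay, at which 1 of the 3 values shown sits, so no number is known for it. From the unsubstituted ring the step of an at least 3.4-fold higher number from compound 1 to compound 2 (0.54 log units; beyond the scatter) is beyond the scatter, while the step of a 1.6-fold lower number from compound 1 to compound 3 (0.20 log units; within the scatter) is within it; the step of an at least 5.4-fold lower number from compound 2 to compound 3 (0.73 log units; beyond the scatter) is again beyond the scatter.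

Compound 4 `CC1=CC[C@@H]([C@@](C)(O)CCCC(C)(C)NC(=S)N/N=C\c2ccc(Cl)cc2)CC1` differs from compound 2 in one place: chloro in place of methyl on an aromatic carbon. Going by the values given here, no measured step exchanges chloro for methyl, so the only bearing comes from compound 2 itself, whose methyl gave an at least 3.4-fold higher number from compound 1 to compound 2 (0.54 log units; beyond the scatter), and from the return toward the other substituted ring in an at least 5.4-fold lower number from compound 2 to compound 3 (0.73 log units; beyond the scatter). Compound 4 is therefore expected to fall somewhere between compound 2 and compound 1, the estimated step being an at least 1.6-fold lower number from compound 2 to compound 4 (0.22 log units; that floor lies within the scatter). The estimate for compound 4 in this assay is 60000 nM, with a range from 20000 nM to 130000 nM, and a real chance that only a limit is returned.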

Compound 4, concentration for total growth inhibition: 15800 nM
The estimate for compound 4 lay 3.8-fold (0.58 log units) above the measured number; the whole stated range lies above it.
By their numbers in this assay, from the lowest: compounds 4, 3 and 1 (each within the scatter of the next). At a limit, above all of these: compound 2.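

In this assay, the exchange of 4-methylphenyl for 4-chlorophenyl, on an aromatic carbon para to a large group, separates two substituents at the same place, with an at least 6.3-fold lower number from compound 2 to compound 4 (0.80 log units; beyond the scatter). Chloro leaves the reading level with the unsubstituted ring, with a 1.8-fold lower number from compound 1 to compound 4 (0.26 log units; within the scatter), and level with the other substituted ring, with a 1.2-fold lower number from compound 3 to compound 4 (0.06 log units; within the scatter), so a substituent at this place does not in itself bring a loss in this series. Compound 2 remains a limit and not a number: the limit of > 100000 nM in this assay, at which 1 of the 4 values shown sits.

The full size of the step from methyl to chloro therefore stays unknown, and the compounds shown do not tell whether the loss belongs to methyl alone or extends to other groups at this place, such as methoxy or an amine. Going by these compounds, what a carboxylic acid at this place would give also stays open.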